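The source may hold more compounds than are shown below. What is called first, only, known or untested is meant among the compounds shown, and "the series" means these compounds.

Compound 1 `O=S(=O)(Nc1ccc(-c2nc3ccccc3o2)cc1)c1cccs1` carries a thiophen-2-yl group on the sulfonyl sulfur of a sulfonamide attached to the shared core. In an assay on cells for inhibition of HSP60/HSP10 (Homo sapiens), with a stated time of 60 min (on this read-out higher numbers stand for weaker inhibition and lower numbers for stronger inhibition), compound 1 gives 63000 nM. Compound 3 `CS(=O)(=O)Nc1ccc(-c2nc3cc(NS(=O)(=O)c4ccc(Cl)s4)ccc3o2)cc1` gives 43000 nM in this assay, a number that sits within the scatter of the figure for compound 1, so no order between the two can be read. Compound 2 `Cc1ccccc1S(=O)(=O)Nc1ccc2oc(-c3ccccc3)nc2c1` gives > 100000 nM in this assay, which is a limit of the assay rather than a number, the one described by the limit of > 100000 nM in this assay, at which 1 of the 3 values shown sits. Going by the values given here, compound 1 thus stands as one of only two numbers in the set, alongside compound 3, with the remaining entry a limit. Among the compounds with values here, no pair of measured compounds differing in a single place is available here, so no measured step is known.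

Compound 4 `O=S(=O)(Nc1ccc(-c2nc3ccccc3o2)cc1)c1cccc(O)c1` has not yet been measured in this assay. It differs from compound 1 by 3-hydroxyphenyl in place of thiophen-2-yl on a sulfonyl sulfur. No measured pair in the set reports the effect of such an exchange, and the compounds shown occupy only a narrow stretch close to the upper limit of this assay. The step of a 1.1-fold lower number from compound 1 to compound 4 (0.02 log units; within the scatter) is therefore expected to be none beyond the scatter. Compound 4 is estimated at 60000 nM, with a range from 20000 nM to 100000 nM.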

Compound 4, half-maximal inhibitory concentration: 62000 nM
Compound 4: middle estimate off by 1.0-fold (0.01 log units), on the low side; the measured number falls inside the stated range.
By their numbers in this assay, from the lowest: compounds 3, 4 and 1 (each within the scatter of the next). At a limit, above all of these: compound 2.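

On a sulfonyl sulfur whose other neighbour is the sulfonamide nitrogen, the series now has its first measured exchange, and in this assay 3-hydroxyphenyl in place of thiophen-2-yl gives a 1.0-fold lower number from compound 1 to compound 4 (0.01 log units; within the scatter). At this position, a five-membered aromatic ring with one hetero atom and a six-membered aromatic ring of carbon only, carrying a hydrogen-bond donor the other group lacks, therefore cannot be told apart in this assay. Compound 2 still counts only as a limit, not a number: the limit of > 100000 nM in this assay, at which 1 of the 4 values shown sits.

Compound 1 and compound 4 both lie in a narrow stretch close to that limit, so this single step cannot show whether the position is insensitive in general or whether these two groups merely share the same high numbers. Going by these compounds, whether a different group on the sulfonyl sulfur, such as a carboxylic acid or an amine on the aromatic ring or a plain alkyl chain in place of the ring, would move the number beyond the scatter remains open.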